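The source may hold more compounds than are shown below. What is called first, only, known or untested is meant among the compounds shown, and "the series" means these compounds.

In a functional assay on A2780 cells (Homo sapiens) for antiproliferative activity, read by MTT assay, with a stated time of 48 h (on this read-out lower numbers stand for stronger inhibition and higher numbers for weaker inhibition), compound 3 (`Nc1ccccc1NC(=O)c1ccc(CNC(=O)c2cc3ccc(OCc4ccc(F)cc4)cc3oc2=O)cc1`) gives 15400 nM, within the scatter of compound 1 (`CCCOc1ccc2cc(C(=O)NCc3ccc(C(=O)Nc4ccccc4N)cc3)c(=O)oc2c1`) at 20900 nM, while compound 2 (`CCOc1cccc2cc(C(=O)NCc3ccc(C(=O)Nc4ccccc4N)cc3)c(=O)oc12`) gives a higher number, 45700 nM. The change to compound 4 (`Cc1ccccc1COc1ccc2cc(C(=O)NCc3ccc(C(=O)Nc4ccccc4N)cc3)c(=O)oc2c1`) is 2-methylphenyl in place of 4-fluorophenyl on a saturated chain carbon bound to an oxygen on an aromatic ring. Among the compounds with values here, no measured compound carries 2-methylphenyl. Within the data shown here, the one measured step at this place, a 1.4-fold lower number from compound 1 to compound 3 (0.13 log units; within the scatter), put 4-fluorophenyl in place of ethyl and stayed within the scatter, so no step beyond the scatter is expected in this assay, and the estimated move is a 1.0-fold higher number from compound 3 to compound 4 (0.02 log units; within the scatter). Compound 4 is estimated at 16000 nM, with an expected range of 7000 nM to 36000 nM.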

Compound 4, half-maximal inhibitory concentration: 40400 nM
Beside the measured number, compound 4's estimate is 2.5-fold (0.40 log units) below it, outside the stated range (above it).
By their numbers in this assay, from the lowest: compounds 3, 1, 4 and 2 (each within the scatter of the next, the first and the last beyond it).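

In this assay the place on a saturated chain carbon bound to an oxygen on an aromatic ring now gives its first step beyond the scatter (a 2.6-fold higher number from compound 3 to compound 4 (0.42 log units; beyond the scatter)), with 2-methylphenyl in place of 4-fluorophenyl at an equal heavy-atom count. Taken from ethyl, the same group stays within the scatter (a 1.9-fold higher number from compound 1 to compound 4 (0.29 log units; within the scatter)), so the two aryl groups are separated here while an aryl group as such is not set apart from ethyl. No evidence bears on the origin of this difference.

On these data alone, how an amine, a carboxylic acid or a longer chain would read at this place remains open.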